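The source may report more compounds than this note shows. Statements on the series, on what has been measured and on what is new or still open speak of the compounds shown alone.

Measured so far in a functional assay on SN12C cells (Homo sapiens) for antiproliferative activity, read by sulforhodamine B assay, with a stated time of 48 h; a higher number here means that more compound is tolerated, a lower number that less compound is tolerated:
- compound 1 `COc1ccc(OC)c(/C=C/c2nnc(Nc3ccc(Cl)cc3)o2)c1`: > 100000 nM (a limit of the assay, not a number)
- compound 2 `COc1ccc(OC)c(/C=C/C(=O)N/N=C/c2ccc(Cl)cc2)c1`: > 100000 nM (likewise a limit of the assay)

Compound 2 therefore stands at the same limit as the only other entry: the limit of > 100000 nM in this assay, at which 2 of the 2 values shown sit. Going by the values given here, no step between measured compounds is available, so nothing yet shows how a single change moves this series.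

Compound 3 `COc1ccc(OC)c(/C=C/C(=O)N/N=C/c2ccccc2)c1` is the next entry. From compound 2 it differs by hydrogen in place of chloro on an aromatic carbon, which sits on an aromatic carbon of a six-membered aromatic ring of carbon only. Both measured compounds sit at the limit, and a change of this size gives no ground to expect a value inside the range. The step of a number no higher from compound 2 to compound 3 (the limit leaves the size open) is expected to be none beyond the scatter. For compound 3 the estimate in this assay is 100000 nM, within 40000 nM to 300000 nM, most likely reported again only as a limit.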

Compound 3, concentration lethal to 50% of the cells: > 100000 nM
Compound 3 gave a limit, no number; the forecaster's own chance of this, stated with the estimate: 85%; the middle value sits exactly at the limit.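

Compound 2 and compound 3 both stand only as limits in this assay, and no step can be read between them. The compounds shown leave open whether any member of the series gives a number in this assay, and what the change from 4-chlorophenyl to phenyl does to such a number.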